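This account rests on a few compounds, and the source may have more. Where it says the series, first, only, none or still open, it means among the compounds named here.

Working notes on the series, following the step from compound 1 to compound 4.

Compound 1 `CC(C)C(c1ccc(-c2ccc3cccc(F)c3c2)[nH]c1=O)N1CCN/C1=N\C#N` is measured in an ADME assay on microsomes from liver (Rattus norvegicus) for metabolic stability (on this read-out lower numbers stand for a shorter-lived compound and higher numbers for a longer-lived compound), at 0.327 h. Within the data shown here, of the two numbers so far, the number for compound 1 is the lower one; compound 2 `CC(C)[C@@H](C[C@H]1CCNC1=O)c1ccc(-c2ccc3cccc(F)c3c2)[nH]c1=O` gives 0.507 h in this assay, and the gap between the two sits within the scatter, so no order between them can be claimed. Compound 3 `CCn1ncc2c(F)cc(-c3ccc(C(CC)(CC)c4ncn(C)n4)c(=O)[nH]3)cc21` gives only a limit in this assay, > 3 h, and not a number. Among the measured compounds shown here, that limit, (the limit of > 3 h in this assay, at which 1 of the 3 values shown sits), is the only other reading available on the series.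

Compound 4 `CC(C)NC(=O)CC(c1ccc(-c2ccc3cccc(F)c3c2)[nH]c1=O)C(C)C` is not yet measured in this assay. It differs from compound 1 in one place: a group of 7 heavy atoms (5 carbon, 1 nitrogen, 1 oxygen; no ring) in place of a group of 8 heavy atoms (4 carbon, 4 nitrogen; one five-membered non-aromatic ring with 2 hetero atoms), on a saturated chain carbon bound to an aromatic carbon and a saturated chain carbon. For the measured compounds named here, no pair of measured compounds covers a change of this kind, so the expectation rests on the two numbers and the structural change alone.

The step from compound 1 to compound 4 in this assay is expected to be small, a 1.5-fold higher number from compound 1 to compound 4 (0.18 log units; within the scatter), and not beyond the scatter. For compound 4 the estimated half-life in this assay is 0.5 h, with a range from 0.2 h to 1.3 h.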

Compound 4, half-life: < 0.0667 h
Compound 4 was reported as a limit (the forecaster's own chance of this, stated with the estimate: 5%); middle value at least 7.4-fold (0.87 log units) away from the limit.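

In this assay, putting (isopropylcarbamoyl)methyl in place of the group with the five-membered non-aromatic ring, on a saturated chain carbon bound to an aromatic carbon and a saturated chain carbon, gives an at least 4.9-fold lower number from compound 1 to compound 4 (0.69 log units; beyond the scatter). Among these compounds, this is the first step read between measured compounds that differ in one place, and it shows that the read-out on the shared core is not indifferent to the group at this place. The full size of the step stays unknown, since compound 4 gives a limit of the assay and not a number: the limit of < 0.0667 h in this assay, at which 1 of the 4 values shown sits.

The change removes the ring and the nitrile and brings in the carbonyl and the isopropyl end together, so the compounds shown do not tell which of these parts goes with the step. A primary amide or a carboxylic acid on the same chain, with the isopropyl end gone, would separate these parts and could give a number rather than a limit at this place.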